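This account rests on a few compounds, and the source may have more. Where it says the series, first, only, none or still open, it means among the compounds named here.

Measured compounds: compound 1 `Cc1cc(O)cc(-c2nn(CC#N)cc2-c2ccnc(-c3ccc(Oc4ccccc4)cc3)c2)c1` with 8070 nM; compound 2 `COc1cc(C)cc(-c2nn(CC#N)cc2-c2ccnc(-c3ccc(N(C)C)cc3)c2)c1` with > 100000 nM.

In a functional assay on IGROV-1 cells (Homo sapiens) for inhibition, read by sulforhodamine B assay, with a stated time of 48 h (on this read-out higher numbers stand for lower toxicity in this test and lower numbers for higher toxicity in this test), compound 1 gives 8070 nM. For compound 2 the result is a limit of the assay, > 100000 nM, so compound 2 stands at the limit of > 100000 nM in this assay, at which 1 of the 2 values shown sits, and no number is known for it. Compound 3 `Cc1cc(O)cc(-c2nn(CC#N)cc2-c2ccnc(-c3ccc(N(C)C)cc3)c2)c1` differs from compound 2 by hydrogen in place of methyl on an oxygen on an aromatic ring. Within the data shown here, no measured step of this kind is known here, so the expected step from compound 2 to compound 3 is estimated as an at least 2.5-fold lower number from compound 2 to compound 3 (0.39 log units; beyond the scatter), toward higher toxicity in this test. Compound 3 is therefore expected at 40000 nM, within 10000 nM to 150000 nM.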

Compound 3, concentration lethal to 50% of the cells: > 100000 nM
Compound 3: no number, only a limit; the forecaster's own chance of this, stated with the estimate: 40%; middle value at least 2.5-fold (0.39 log units) from the limit.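

In this assay compound 3 gives > 100000 nM, a limit of the assay and not a number. Among these compounds, the change from methoxy to hydroxy therefore cannot be read, with both ends at a limit: the limit of > 100000 nM in this assay, at which 2 of the 3 values shown sit. With the 3-hydroxy-5-methylphenyl group shared, dimethylamino in place of phenoxy on an aromatic carbon gives an at least 12-fold higher number from compound 1 to compound 3 (1.09 log units; beyond the scatter), the first single change that can be read here, toward lower toxicity in this test.

As far as these compounds go, whether methoxy in place of hydroxy counts when phenoxy is present stays open. So does where a cyclic amine such as morpholine would fall in place of phenoxy.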